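This account rests on a few compounds, and the source may have more. Where it says the series, first, only, none or still open, it means among the compounds named here.

Compound 1 `COc1ccc(Cn2c(-c3ccc(C)cc3)c(Br)c(=O)c3cc([N+](=O)[O-])ccc32)cc1` gives 2430 nM in an assay on isolated protein for inhibition of Intestinal-type alkaline phosphatase (Bos taurus), read by spectrophotometry, with stated times of 7 min and 15 min; a higher number here means a weaker inhibitor, a lower number a stronger inhibitor. Compound 2 `COc1ccc(Cn2c(-c3ccc(C)cc3)c(-c3cc(C)cc(C)c3)c(=O)c3cc([N+](=O)[O-])ccc32)cc1` gives 28700 nM in this assay. Compound 3 `COc1ccc(Cn2c(-c3ccc(C)cc3)c(-c3ccc(C(F)(F)F)cc3)c(=O)c3cc([N+](=O)[O-])ccc32)cc1` gives 8340 nM in this assay.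

Compound 3 stands second highest of the three numbers; its nearest neighbour is shown by a 3.4-fold higher number from compound 1 to compound 3 (0.54 log units; beyond the scatter) and its furthest by a 3.4-fold lower number from compound 2 to compound 3 (0.54 log units; beyond the scatter). Compound 4 `COc1ccc(Cn2c(-c3ccc(C)cc3)c(C(F)(F)F)c(=O)c3cc([N+](=O)[O-])ccc32)cc1` differs from compound 3 by trifluoromethyl in place of 4-(trifluoromethyl)phenyl on an aromatic carbon. For the measured compounds named here, the steps that bear on this are those exchanging bromo for an aryl group: a 12-fold higher number from compound 1 to compound 2 (1.07 log units; beyond the scatter) and a 3.4-fold higher number from compound 1 to compound 3 (0.54 log units; beyond the scatter). Both aryl groups gave higher numbers than the bromo compound, and the trifluoromethyl of compound 4 is, like bromo, a group with no ring, so compound 4 is expected to move back toward compound 1 with a modest lower number, a 2.8-fold lower number from compound 3 to compound 4 (0.44 log units; beyond the scatter). Compound 4 is therefore estimated at 3000 nM, with a range from 1000 nM to 10000 nM.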

Compound 4, half-maximal inhibitory concentration: 4580 nM
Compound 4: middle estimate off by 1.5-fold (0.18 log units), on the low side; the measured number falls inside the stated range.
By their numbers in this assay, from the lowest: compounds 1, 4 and 3 (each within the scatter of the next, the first and the last beyond it); then compound 2.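

In this assay trifluoromethyl cannot be told apart from either 4-(trifluoromethyl)phenyl, with a 1.8-fold lower number from compound 3 to compound 4 (0.26 log units; within the scatter), or bromo, with a 1.9-fold higher number from compound 1 to compound 4 (0.28 log units; within the scatter), so at this position the removal of the six-membered aromatic ring from compound 3 brings no change beyond the scatter. Only 3,5-dimethylphenyl stands clearly apart from trifluoromethyl, with a 6.3-fold lower number from compound 2 to compound 4 (0.80 log units; beyond the scatter), so the two aryl groups differ in how they compare with it. The compounds shown leave open whether an amine, a carboxylic acid or a longer chain at this position would give a lower number than bromo or trifluoromethyl. No measurement offered here accounts for these steps.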